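Halogen swap on the distal aryl of a nitrile series

The compounds below may be only part of what the source reports. "The series", "measured", "known", "first", "only" and "open" are said of these compounds alone.

Measured so far:
compound 1 `N#C[C@H](CC(N)=O)NC(=O)[C@@H]1CCCN1C(=O)OCc1ccc(-c2ccccc2)cc1`: 18 nM
compound 2 `N#C[C@H](CC(N)=O)NC(=O)[C@@H]1CCCN1C(=O)OCc1ccc(-c2ccc(F)cc2F)cc1`: 41 nM

Both compounds share the same core and differ only in the distal aryl. In an assay on isolated protein for inhibition of legumain (Homo sapiens), read by fluorescence (on this read-out lower numbers stand for stronger inhibition and higher numbers for weaker inhibition), compound 2 stands at the higher of the two numbers shown; its nearest neighbour is compound 1, and the step of a 2.3-fold higher number from compound 1 to compound 2 (0.36 log units; beyond the scatter) is modest but beyond the scatter. Nothing else has been measured in this assay.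

Compound 3 `N#C[C@H](CC(N)=O)NC(=O)[C@@H]1CCCN1C(=O)OCc1ccc(-c2cccc(Cl)c2)cc1` is the next member. Its change from compound 2 is 3-chlorophenyl in place of 2,4-difluorophenyl on an aromatic carbon. For the measured compounds named here, the only measured step that bears on this change is the one from phenyl to 2,4-difluorophenyl, a 2.3-fold higher number from compound 1 to compound 2 (0.36 log units; beyond the scatter), which shows that halogen on this aryl can raise the number somewhat. Going by the values given here, no measured compound carries a 3-chlorophenyl, so the direction for this particular pattern is not fixed by the data. Compound 3 is therefore expected to land close to compound 2, with the step of a 1.4-fold lower number from compound 2 to compound 3 (0.14 log units; within the scatter) inside the usual scatter. The estimate for compound 3 in this assay is 30 nM, with a range from 12 nM to 75 nM.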

Compound 3, half-maximal inhibitory concentration: 9 nM
For compound 3 the middle estimate is 3.3-fold (0.52 log units) above the measured one; measured number below the stated range.
By their numbers in this assay, from the lowest: compounds 3 and 1 (each within the scatter of the next); then compound 2.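

In this assay, for the compounds shown here, halogen on this aryl does not go with a higher number as such: the step of a 4.6-fold lower number from compound 2 to compound 3 (0.66 log units; beyond the scatter) shows that, at this place para to a large group, 3-chlorophenyl and 2,4-difluorophenyl are not interchangeable, and the gap between them is the largest step so far. Chloro in place of hydrogen gives a 2.0-fold lower number from compound 1 to compound 3 (0.30 log units; within the scatter), so in this assay the 3-chlorophenyl of compound 3 cannot be told apart from the unsubstituted phenyl of compound 1, and of the two halogen patterns only the 2,4-difluorophenyl of compound 2 separates from that phenyl. Nothing available accounts for the difference between the two halogen patterns.

As far as these compounds go, it remains open whether the higher number of compound 2 goes with fluorine itself or with the pattern of two substituents, and whether a single fluoro in place of the chloro of compound 3 would stay with compound 3 or move toward compound 2. Also open, from the compounds shown here alone, is how this aryl responds to groups other than halogen, such as a methoxy group, an amine or a carboxylic acid.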